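Phenyl swaps on a shared core: estimate for compound 4

A few compounds are considered here, and "the series" means these few. Any claim that something is new, unique, unknown or untested is made for them only; others in the source may bear on it.

Measured so far in a functional assay on MDA-MB-231 cells (Homo sapiens) for inhibition, read by CCK-8 assay, with a stated time of 48 h; a lower number here means a stronger inhibitor of growth, a higher number a weaker inhibitor of growth
compound 1 `COc1ccccc1CNc1nc(Nc2ccc(N3CCN(C)CC3)cn2)ncc1Cl` gives 29300 nM
compound 2 `CC(C)c1ccc(Nc2nc(Nc3ccc(N4CCN(C)CC4)cn3)ncc2Cl)cc1` gives 7020 nM
compound 3 `CC(C)c1ccccc1Nc1nc(Nc2ccc(N3CCN(C)CC3)cn2)ncc1Cl` gives 4090 nM

Compound 3 (4090 nM) and compound 2 (7020 nM) lie within the scatter of each other, and both stand clearly under compound 1 (29300 nM). Compound 4 `Cc1cc(C)c(Nc2nc(Nc3ccc(N4CCN(C)CC4)cn3)ncc2Cl)c(C)c1` has 2,4,6-trimethylphenyl in place of 2-isopropylphenyl on a nitrogen on an aromatic ring. Two measured steps replaced 2-methoxybenzyl with an isopropylphenyl group and were modest (a 4.2-fold lower number from compound 1 to compound 2 (0.62 log units; beyond the scatter) and a 7.2-fold lower number from compound 1 to compound 3 (0.86 log units; beyond the scatter)). Neither matches the present change, since compound 4 keeps a substituted phenyl on that nitrogen. The nearest guide is the exchange between the two isopropylphenyl groups (a 1.7-fold lower number from compound 2 to compound 3 (0.23 log units; within the scatter)), which stayed within the scatter. Going by the values given here, the series holds no measured trimethylphenyl example, so the guidance is thin, and no step beyond the scatter is expected in this assay in either direction. The expected step is small (a 1.1-fold higher number from compound 3 to compound 4 (0.04 log units; within the scatter)). For compound 4 the estimated value is 4500 nM (expected range 1800 nM to 11000 nM).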

Compound 4, concentration for 50% growth inhibition: 21000 nM
Compound 4: the middle estimate sits 4.7-fold (0.67 log units) below what was measured, outside the stated range (above it).
By their numbers in this assay, from the lowest: compounds 3 and 2 (each within the scatter of the next); then compounds 4 and 1 (each within the scatter of the next).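

In this assay this nitrogen does not accept every substituted phenyl alike: 2,4,6-trimethylphenyl, which has the same atoms as 2-isopropylphenyl joined differently, gives a 5.1-fold higher number from compound 3 to compound 4 (0.71 log units; beyond the scatter) and a 3.0-fold higher number from compound 2 to compound 4 (0.48 log units; beyond the scatter), so the position separates groups in a way that the two isopropylphenyl compounds did not. The advantage that both isopropylphenyl groups held over 2-methoxybenzyl is absent here, with a 1.4-fold lower number from compound 1 to compound 4 (0.14 log units; within the scatter). Nothing available on these compounds accounts for this loss.

Which methyl groups of 2,4,6-trimethylphenyl carry the loss remains open, and 2,6-dimethylphenyl and 4-methylphenyl on the same nitrogen would help to separate them. Also open, on these data alone, is whether a saturated ring such as cyclohexyl would hold the level of compound 3 or fall to that of compound 4.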